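This account rests on a few compounds, and the source may have more. Where it says the series, first, only, none or still open, it means among the compounds named here.

Within the data shown here, compound 2 `COc1ccc(C(=O)/C=C/c2cc(-c3cc(OC)c(OC)c(OC)c3)n[nH]2)cc1` gives the higher of the two numbers known in a functional assay on U-251 cells (Homo sapiens) for cytotoxicity, read by sulforhodamine B assay, with a stated time of 48 h, tested at 100 uM; on this read-out higher numbers stand for a weaker effect at the one concentration tested and lower numbers for a stronger effect: compound 2 gives -25%, while compound 1 `COc1cc(-c2cc(/C=C/C(=O)c3ccc(N)cc3)[nH]n2)cc(OC)c1OC` gives -98%. Compound 3 `COc1cc(-c2cc(/C=C/C(=O)c3ccc(F)c(F)c3)[nH]n2)cc(OC)c1OC` differs from compound 2 by 3,4-difluorophenyl in place of 4-methoxyphenyl on a carbonyl carbon. Among the measured compounds shown here, no measured step changes that same ring in that same way; the only step known, a number 73 percentage points higher from compound 1 to compound 2 (beyond the scatter), shows that altering the group on this ring can move this assay a great deal. The direction here is therefore uncertain, and compound 3 is expected to lie near compound 2 with a wide range, a number 10 percentage points lower from compound 2 to compound 3 (within the scatter). The estimate for compound 3 is -35%, between -95% and 5%.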

Compound 3, a percentage reported as activity, at one concentration (the size of the read-out at that concentration, not a potency): -29%
The estimate for compound 3 lay 6 percentage points below the measured number, within the range that was stated.
By their numbers in this assay, from the lowest: compound 1; then compounds 3 and 2 (each within the scatter of the next).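

In this assay replacing 4-methoxyphenyl with 3,4-difluorophenyl on a carbonyl carbon gives a number 4 percentage points lower from compound 2 to compound 3 (within the scatter) and so the two groups cannot be told apart here, although they carry different substituents. Replacing 4-aminophenyl with the same 3,4-difluorophenyl gives a number 69 percentage points higher from compound 1 to compound 3 (beyond the scatter) and so 4-aminophenyl alone stands out, with the stronger effect of the three groups.

As far as these compounds go, whether a hydroxyl group or another amine such as dimethylamino on this ring would keep that strong effect remains open. Nothing available explains why 4-aminophenyl behaves differently.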